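A few compounds are considered here, and "the series" means these few. Any claim that something is new, unique, unknown or untested is made for them only; others in the source may bear on it.

Measured so far in a functional assay on NALM-6 cells (Homo sapiens) for cytotoxicity, read by MTT assay, with a stated time of 48 h; on this read-out higher numbers stand for weaker inhibition and lower numbers for stronger inhibition:
compound 1 `O=C(Nc1cc(C(F)(F)F)ccc1N1CCCC1)c1cccnc1`: "not active" (no number reported)
compound 2 `CCN(CC)c1ccc(C(F)(F)F)cc1NC(=O)c1cccnc1`: 63200 nM
compound 3 `O=C(Nc1cc(C(F)(F)F)ccc1Nc1ccc(Br)cc1)c1cccnc1`: 17000 nM

Compound 1 stands without a number: in this assay compound 1 is reported only as "not active" (no number reported), which is a statement of the assay and not a measured value. The two compounds that do carry numbers are weak; compound 2 gives 63200 nM and compound 3 gives 17000 nM. Among the compounds with values here, the one step between measured compounds, a 3.7-fold lower number from compound 2 to compound 3 (0.57 log units; beyond the scatter), concerns the group on the aromatic carbon of the core and touches nothing on the carbonyl side.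

Compound 4 `O=C(Nc1cc(C(F)(F)F)ccc1N1CCCC1)c1ccccc1` differs from compound 1 by phenyl in place of pyridin-3-yl on a carbonyl carbon. Within the data shown here, no measured step bears on this change; the amide part of the core is the same in compound 1, compound 2 and compound 3. With compound 1 giving no number and the rest of the series weak, nothing in these data points to compound 4 rising out of that range in this assay. Compound 4 is therefore expected to remain weak, most probably again without a reported number, with an estimate of 100000 nM and a range of 30000 nM to 300000 nM.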

Compound 4, half-maximal inhibitory concentration: "not active" (no number reported)
Compound 4 has no reported number here, so the estimate cannot be set against anything.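

Compound 1 and compound 4 both stand without a number, so no step can be read for phenyl in place of pyridin-3-yl on the carbonyl carbon. The compounds shown leave open whether this change alters the read-out in this assay at all. No supporting measurement bears on this result.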